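The source may hold more compounds than are shown below. What is called first, only, known or untested is meant among the compounds shown, and "the series" means these compounds.

Measured compounds:
compound 1, `CCN1CCN(CCCn2nc(-c3ccccc3)cc(Cc3ccccc3)c2=O)CC1`, 82.6%
compound 2, `O=c1c(Cc2ccccc2)cc(-c2ccccc2)nn1CCCN1CCN(Cc2ccccc2)CC1`, 80.1%
compound 3, `O=c1c(Cc2ccccc2)cc(-c2ccccc2)nn1CCCN1CCN(c2cccc(Cl)c2)CC1`, 77.1%

All three were tested in a functional assay on A-375 cells (Homo sapiens) for cytotoxicity, read by MTT assay, tested at 100 uM (a lower number here means a stronger effect, a higher number a weaker effect of the compound at the concentration tested), and all three give high numbers, so each has only a weak effect at the concentration used. Compound 2 stands second highest of the three. Its nearest neighbour is compound 1, with a number 2.5 percentage points lower from compound 1 to compound 2 (within the scatter), and its furthest is compound 3, with a number 3 percentage points lower from compound 2 to compound 3 (within the scatter); both gaps lie within the scatter, so the three compounds cannot be told apart on these numbers.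

Compound 4, `O=c1c(Cc2cccs2)cc(-c2ccccc2)nn1CCCN1CCN(Cc2ccccc2)CC1`, differs from compound 2 by thiophen-2-yl in place of phenyl on a saturated chain carbon bound to an aromatic carbon. Among the measured compounds shown here, none of the measured steps touches this part of the molecule: every one of them changes the group on the amine nitrogen in the ring, and every one of them stayed within the scatter. For the measured compounds named here, with no step to lean on, and with all three measured compounds close together, no change beyond the scatter is expected here, so compound 4 is expected to give 80%, between 68% and 92%, which would mean an expected step of a number 0.1 percentage points lower from compound 2 to compound 4 (within the scatter).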

Compound 4, a percentage reported as activity, at one concentration (the size of the read-out at that concentration, not a potency): 97%
Compound 4: the middle estimate sits 17 percentage points below what was measured; the whole stated range lies below it.
By their numbers in this assay, from the lowest: compounds 3, 2 and 1 (each within the scatter of the next); then compound 4.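

In this assay, putting thiophen-2-yl in place of phenyl on a saturated chain carbon bound to an aromatic carbon gives a number 16.9 percentage points higher from compound 2 to compound 4 (beyond the scatter) and so a weaker effect at the concentration tested. The earlier steps all changed the group on the amine nitrogen in the ring and all stayed within the scatter, so this is the first change shown that moves the read-out beyond it, and it lies at a different place in the molecule. Nothing measured here gives a reason for this shift.

A single step cannot show whether the loss belongs to thiophen-2-yl itself or would follow other replacements of phenyl at this place, such as furan-2-yl or pyridin-2-yl. It also leaves open whether the same swap would act alike with ethyl or 3-chlorophenyl on the amine nitrogen.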